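The source may report more compounds than this note shows. Statements on the series, on what has been measured and on what is new or still open speak of the compounds shown alone.

In an ADME assay on BJ cells (Homo sapiens) for cytotoxicity, read by CellTiter-Glo and resazurin assay, with a stated time of 72 h (a higher number here means that more compound is needed for the effect, a lower number that less compound is needed), compound 1 `CC(C)N(Cc1cccc(OCCCCCC(=O)O)c1)C(=O)c1ccccc1` gives only a limit of the assay, > 26000 nM. Compound 2 `CC(C)N(Cc1cccc(OCCCCCC(=O)O)c1)C(=O)c1ccc(-c2cccc3ccccc23)cc1` also gives a limit, < 1.3 nM. The change between the two, an at least 20000-fold lower number from compound 1 to compound 2 (4.30 log units; beyond the scatter), is a large step. Compound 3 `CCOC(=O)CCCCCOc1cccc(CN(C(=O)c2ccc(-c3cccc4ccccc34)cc2)C(C)C)c1` again returns a limit, > 26000 nM. The step of an at least 20000-fold higher number from compound 2 to compound 3 (4.30 log units; beyond the scatter) is just as large in the opposite direction. Compound 3 thus stands at the upper limit, where two of the three values sit (the limit of > 26000 nM in this assay, at which 2 of the 3 values shown sit), and no exact number is known for it.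

Compound 4 `CCOC(=O)CCCCCOc1cccc(CN(C(=O)c2ccc(-c3ccc4cc[nH]c4c3)cc2)C(C)C)c1` keeps the ethyl ester of compound 3 and differs from it in one place (1H-indol-6-yl in place of naphthalen-1-yl on an aromatic carbon). Going by the values given here, no measured step tests this swap on its own. The step of an at least 20000-fold lower number from compound 1 to compound 2 (4.30 log units; beyond the scatter) shows that the group on this aromatic carbon can move the number a great deal, while the step of an at least 20000-fold higher number from compound 2 to compound 3 (4.30 log units; beyond the scatter) shows that the ethyl ester, which compound 4 retains, carries the number to the upper limit even with naphthalen-1-yl present. For compound 4 the number in this assay is therefore expected to stay near the upper limit, estimated at 26000 nM with a range of 5000 nM to 100000 nM. The step of a number no higher from compound 3 to compound 4 (the limit leaves the size open) is accordingly expected to be none beyond the scatter.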

Compound 4, half-maximal effective concentration: > 26000 nM
Compound 4 ended at the assay's limit; the forecaster's own chance of this, stated with the estimate: 80%; the middle value lies on the limit itself.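

Compound 4 sits at the same limit of this assay as compound 3: the limit of > 26000 nM in this assay, at which 3 of the 4 values shown sit. With only a limit for each, no step can be read between compound 3 and compound 4. The compounds shown leave open how 1H-indol-6-yl and naphthalen-1-yl compare, with the ethyl ester or without it.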